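A few compounds are considered here, and "the series" means these few. Any claim that something is new, unique, unknown or untested is made for them only; others in the source may bear on it.

Working notes on the series. Three compounds sharing one core have so far been run in a functional assay on Hs-578T cells (Homo sapiens) for cytotoxicity, read by sulforhodamine B assay, with a stated time of 48 h; on this read-out lower numbers stand for stronger inhibition of growth and higher numbers for weaker inhibition of growth. Compound 1 `ClCc1ccc(Cn2cnc3c(Cl)ncnc32)cc1` gives 38900 nM in this assay. Compound 2 `Nc1nc(Cl)c2ncn(Cc3ccccc3CCl)c2n1` gives 77600 nM in this assay. Compound 3 `ClCc1ccccc1Cn1cnc2ncnc(Cl)c21` gives 6020 nM in this assay. On these numbers compound 2 stands highest of the three; compound 1 sits within the scatter of it, so no order between those two can be read, whereas compound 3 lies beyond the scatter below it. For the measured compounds named here, no step between two measured compounds differing in a single place has been worked out, so the measured set offers no direct precedent for the change at hand.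

Compound 4 `ClCc1ccccc1Cn1cnc2c(Cl)nc(Cl)nc21` is not yet measured. It differs from compound 2 by chloro in place of amino on an aromatic carbon. Compound 4 therefore keeps the side chain of compound 2 and of compound 3, and at the carbon that bears the amino in compound 2 it carries a chloro instead. Given that compound 3 gives 6020 nM in this assay against compound 2 at 77600 nM, compound 4 is expected to land nearer compound 3. The expected step of an 8.6-fold lower number from compound 2 to compound 4 (0.94 log units; beyond the scatter) is taken as a downward one beyond the scatter. Compound 4 is estimated at 9000 nM, within a range of 2500 nM to 35000 nM.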

Compound 4, concentration for total growth inhibition: 3540 nM
Estimate against measurement, compound 4: 2.5-fold (0.41 log units) above; the measured number falls inside the stated range.
By their numbers in this assay, from the lowest: compounds 4 and 3 (each within the scatter of the next); then compounds 1 and 2 (each within the scatter of the next).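

In this assay the series now has its first step in a single place: chloro in place of amino on an aromatic carbon between two ring nitrogen atoms gives a 22-fold lower number from compound 2 to compound 4 (1.34 log units; beyond the scatter), a large step beyond the scatter, so this position is not indifferent to the group it carries. With the same side chain, compound 3 at 6020 nM and compound 4 at 3540 nM lie within the scatter of each other, so no order can be read between the chloro compound and the compound with hydrogen at this carbon, and of these three compounds only the amino compound stands apart. Nothing at hand bears on why the amino and chloro compounds differ so widely.

Going by these compounds, it remains open whether other groups at this carbon, such as methoxy, methylamino or fluoro, would stand with the amino compound or with compound 3 and compound 4. Also open, on these data alone, is whether the same exchange of amino for chloro would give a step of similar size with the side chain of compound 1.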